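Working notes: imidazopyridine-type series, whole-animal inhibition

The compounds below may be only part of what the source reports. "The series", "measured", "known", "first", "only" and "open" are said of these compounds alone.

Measured so far:
compound 1 `Cc1nc2c(OCc3ccccc3)cccn2c1N`: 96%
compound 2 `Cc1nc2c(OCc3ccccc3F)cccn2c1N`: 93%
compound 3 `Cc1nc2c(OCc3ccccn3)cccn2c1N`: 15%

In a functional assay on the whole organism with Canis familiaris (Canis lupus familiaris) as the target, at a dose of 8 mg/kg by the oral route (a higher number here means a stronger effect of the compound at the dose given, a lower number a weaker effect), compound 1 gives 96% and stands highest of the three numbers. Compound 2 lies nearest, with a number 3 percentage points lower from compound 1 to compound 2 (within the scatter), so the two cannot be ordered. For the measured compounds named here, compound 3 lies furthest, with a number 81 percentage points lower from compound 1 to compound 3 (beyond the scatter), the only change of consequence seen so far.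

Compound 4 `Cc1nc2c(OCc3ccccc3)cccn2c1CN` is not yet measured. It differs from compound 1 as follows: aminomethyl in place of amino on an aromatic carbon. Going by the values given here, both measured steps concern the group on the oxygen side of the shared core, and neither touches the five-membered ring; no measured step therefore bears on this change, and its size and direction cannot be read from the series. The change keeps the donor and acceptor count but moves the nitrogen one carbon out from the ring, so some loss is held possible without support from data. Compound 4 is accordingly estimated at 60%, within 15% to 95%. This estimate means an expected step of a number 36 percentage points lower from compound 1 to compound 4 (beyond the scatter), stated with low confidence.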

Compound 4, a percentage reported as inhibition, in the whole organism at one dose (the size of the read-out at that dose, not a potency): 9%
Compound 4: middle estimate off by 51 percentage points, on the high side; the whole stated range lies above it.
By their numbers in this assay, from the lowest: compounds 4 and 3 (each within the scatter of the next); then compounds 2 and 1 (each within the scatter of the next).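

Replacing amino with aminomethyl on this aromatic carbon of the five-membered ring gives, in this assay, a number 87 percentage points lower from compound 1 to compound 4 (beyond the scatter), so the whole-animal effect depends on this position as well as on the group on the oxygen side of the shared core. The change adds a single carbon and leaves the hydrogen-bond donor count, acceptor count and net charge unchanged, so these counts do not separate compound 1 from compound 4. Nothing at hand accounts for the loss.

The compounds shown leave open whether any other group is accepted here: a methylamino, an acetamido or a hydroxymethyl group in place of amino would bear on this. Also open, from the compounds shown here alone, is whether the methyl group on the same ring can give way to an ethyl group.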